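The compounds below may be only part of what the source reports. "The series", "measured", "known", "first", "only" and "open" are said of these compounds alone.

Measured in a functional assay on Vero cells (Chlorocebus sabaeus) for inhibition; a higher number here means a weaker inhibitor, a lower number a stronger inhibitor:
Compound 1 `OC[C@H]1C=C(F)[C@H](n2cnc3c(O)ncnc32)O1`: > 100000 nM (a limit)
Compound 2 `Nc1ncnc2c1ncn2[C@H]1O[C@@H](CO)C=C1F`: > 100000 nM (a limit)

In this assay compound 2 gives > 100000 nM, which is a limit of the assay and not a number. That places compound 2 at the limit of > 100000 nM in this assay, at which 2 of the 2 values shown sit. Compound 3 `OC[C@H]1C=C(F)[C@@H](n2cnc3c(O)ncnc32)O1` has not yet been measured. Relative to compound 2 it carries hydroxy in place of amino on an aromatic carbon, (hydroxy in place of amino on an aromatic carbon). Among the measured compounds shown here, no measured pair shows this change on its own, so the expectation in this assay is for no step beyond the scatter and no particular direction. Compound 1 also carries hydroxy on that carbon and gives > 100000 nM, again a limit. The expected step of a number no higher from compound 2 to compound 3 (the limit leaves the size open) is therefore small. For compound 3 the estimate is 100000 nM, with an expected range of 30000 nM to 300000 nM.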

Compound 3, half-maximal inhibitory concentration: > 100000 nM
Compound 3: no number, only a limit; the forecaster's own chance of this, stated with the estimate: 85%; the middle value lies on the limit itself.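

In this assay compound 3 gives > 100000 nM, which is a limit and not a number. The steps to it from compound 1 and compound 2 cannot be read: the limit of > 100000 nM in this assay, at which 3 of the 3 values shown sit.

The compounds shown leave open whether hydroxy in place of amino, or the difference in configuration between compound 1 and compound 3, changes inhibition at all.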